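The source may hold more compounds than are shown below. What is called first, only, known or untested is meant among the compounds shown, and "the series" means these compounds.

Measured in a functional assay on RS4-11 cells (Homo sapiens) for inhibition, read by CCK-8 assay, with a stated time of 48 h; a higher number here means a weaker inhibitor, a lower number a stronger inhibitor:

- Compound 1 `O=C(NCCNS(=O)(=O)c1ccc(-c2ccccc2O[C@H]2CC[C@H](O)CC2)s1)Nc1ccc([N+](=O)[O-])cc1`: 4100 nM
- Compound 2 `O=C(NCCNS(=O)(=O)c1ccc(-c2ccccc2OCc2ccccc2)s1)Nc1cc(Cl)cc(Cl)c1`: > 20000 nM (a limit, not a number)

Compound 2 stands at a limit of this assay, > 20000 nM, and so has no exact value. Compound 3 `O=C(NCCNS(=O)(=O)c1ccc(-c2ccccc2O[C@H]2CC[C@H](O)CC2)s1)Nc1cc(Cl)cc(Cl)c1` keeps the rest of compound 2 and carries 4-hydroxycyclohexyl in place of benzyl on an oxygen on an aromatic ring. Among the measured compounds shown here, no measured pair of compounds differs in one place only, so the size of this change has not been observed directly. The expectation rests on a compound that differs from compound 3 elsewhere but bears the same 4-hydroxycyclohexyl on that oxygen: compound 1 gives 4100 nM. A move towards stronger inhibition, beyond the usual scatter, is therefore expected in this assay, although a result that again reaches the limit remains possible. The expected change is an at least 3.6-fold lower number from compound 2 to compound 3 (0.56 log units; beyond the scatter). Compound 3 is estimated at 5500 nM, with an expected range from 1500 nM to 18000 nM.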

Compound 3, half-maximal inhibitory concentration: 14100 nM
Compound 3: the middle estimate sits 2.6-fold (0.41 log units) below what was measured; the measured number falls inside the stated range.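

In this assay, among the compounds shown here, putting 4-hydroxycyclohexyl in place of benzyl on an oxygen on an aromatic ring gives an at least 1.4-fold lower number from compound 2 to compound 3 (0.15 log units; that floor lies within the scatter), the first direct reading of this change, and it shows that the swap brings the compound within the range the assay can put a number on, though the floor alone does not establish a change beyond the scatter. As far as these compounds go, compound 2 has only a limit and not a number, and the true size of the step stays unknown because of that limit: the limit of > 20000 nM in this assay, at which 1 of the 3 values shown sits. The same 4-hydroxycyclohexyl also proves not to fix the level by itself, since 3,5-dichlorophenyl in place of 4-nitrophenyl on an amide-type nitrogen gives a 3.4-fold higher number from compound 1 to compound 3 (0.54 log units; beyond the scatter), so the group on that nitrogen counts as well.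

The compounds shown leave open whether the hydroxyl contributes anything, as plain cyclohexyl or 4-aminocyclohexyl on the same oxygen would tell. They also leave open whether benzyl paired with 4-nitrophenyl would give a number in this assay, which would show how far the two changes depend on each other.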